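Shifting a Chlorine on the Benzyl Group: Cytotoxicity Outlook

The source may report more compounds than this note shows. Statements on the series, on what has been measured and on what is new or still open speak of the compounds shown alone.

Measured in an ADME assay on Huh-5-2 cells (Homo sapiens) for cytotoxicity, read by WST assay, with a stated time of 3 days; a higher number here means that more compound is tolerated, a lower number that less compound is tolerated:
Compound 1, `O=c1c(OCc2ccccc2Br)c(-c2ccccc2)oc2cc(O)cc(O)c12`, gives 12000 nM.
Compound 2, `Cc1ccccc1COc1c(-c2ccccc2)oc2cc(O)cc(O)c2c1=O`, gives 55000 nM.
Compound 3, `O=c1c(OCc2cccc(Cl)c2)c(-c2ccccc2)oc2cc(O)cc(O)c12`, gives 46000 nM.

Compound 3 stands second highest of the three. It sits well apart from compound 1, as a 3.8-fold higher number from compound 1 to compound 3 (0.58 log units; beyond the scatter) shows, yet close to compound 2, since a 1.2-fold lower number from compound 2 to compound 3 (0.08 log units; within the scatter) lies within the scatter. Compound 4, `O=c1c(OCc2ccc(Cl)cc2)c(-c2ccccc2)oc2cc(O)cc(O)c12`, differs from compound 3 only in that (4-chlorophenyl in place of 3-chlorophenyl on a saturated chain carbon bound to an oxygen on an aromatic ring).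

Two measured steps change the same benzyl group and so bear on this: the modest rise in a 3.8-fold higher number from compound 1 to compound 3 (0.58 log units; beyond the scatter), and the flat a 1.2-fold lower number from compound 2 to compound 3 (0.08 log units; within the scatter). Among the measured compounds shown here, no measured pair shifts a chlorine alone. Compound 4 is therefore expected to show no step beyond the scatter, a 1.0-fold lower number from compound 3 to compound 4 (0.01 log units; within the scatter). The estimated value for compound 4 is 45000 nM, with a range from 20000 nM to 100000 nM.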

Compound 4, half-maximal cytotoxic concentration: 36000 nM
For compound 4 the middle estimate is 1.3-fold (0.10 log units) above the measured one, and the stated range covers the measured number.
By their numbers in this assay, from the lowest: compound 1; then compounds 4, 3 and 2 (each within the scatter of the next).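

In this assay, shifting the chlorine alone leaves no step beyond the scatter (a 1.3-fold lower number from compound 3 to compound 4 (0.11 log units; within the scatter)), so 3-chlorophenyl and 4-chlorophenyl cannot be told apart at this saturated chain carbon. The 2-methylphenyl group cannot be told apart from 4-chlorophenyl either (a 1.5-fold lower number from compound 2 to compound 4 (0.18 log units; within the scatter)), while the 2-bromophenyl group remains clearly separate (a 3.0-fold higher number from compound 1 to compound 4 (0.48 log units; beyond the scatter)). Nothing available here explains these numbers.

Still open, on these data alone, is whether an amine or a carboxylic acid on this phenyl ring would keep the number in the same range. A longer chain between the oxygen and the phenyl ring is equally untested in these compounds.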